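Carbamoyl for Benzyl on the Saturated Ring of Compound 3

The source may hold more compounds than are shown below. What is called first, only, known or untested is meant among the compounds shown, and "the series" means these compounds.

Compound 1 `COc1cc2nc(N3CCC(N4CCCC4)CC3)nc(N(C)C)c2cc1OC`: < 0%
Compound 2 `CCNc1nc(N2CCC(N3CCCC3)CC2)nc2cc(OC)c(OC)cc12`: < 0%
Compound 3 `COc1cc2nc(N3CCC(Cc4ccccc4)CC3)nc(NC3CCCCCC3)c2cc1OC`: < 0%

Of the compounds shown here, three have been measured in an in vitro assay on B300-19 cells for displacement of a labelled ligand from C-C chemokine receptor type 4 (Homo sapiens), tested at 1 uM; on this read-out lower numbers stand for less inhibition and higher numbers for more inhibition at the one concentration tested (going by the name of the read-out). In this assay compound 1 gives < 0%, which is a limit of the assay rather than a number. Compound 2 likewise returns a limit, < 0%. Compound 3 also returns a limit, < 0%. For the measured compounds named here, the one single-place step among them, a step that the two limits leave unreadable from compound 1 to compound 2, cannot be read between two limits. Where compound 3 stands is therefore known only as far as the limit of < 0% in this assay, at which 3 of the 3 values shown sit.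

Compound 4 `COc1cc2nc(N3CCC(C(N)=O)CC3)nc(NC3CCCCCC3)c2cc1OC` differs from compound 3 by carbamoyl in place of benzyl on a saturated ring carbon. Going by the values given here, none of the measured steps bears on this change, and with every value so far at a limit, no movement beyond the scatter is expected in either direction. Compound 4 is accordingly estimated at 0%, with a range from -10% to 12%. The step of a number no lower from compound 3 to compound 4 (the limit leaves the size open) is thus expected to be essentially none.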

Compound 4, a percentage reported as inhibition, at one concentration (the size of the read-out at that concentration, not a potency): < 0%
Compound 4 gave a limit, no number (the forecaster's own chance of this, stated with the estimate: 75%); the middle value sits exactly at the limit.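

Compound 3 and compound 4 each return a limit, so no step can be read between them. The compounds shown leave open what structure would give a readable number in this assay, as everything rests at one point: the limit of < 0% in this assay, at which 4 of the 4 values shown sit.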